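The compounds below may be only part of what the source reports. "The series", "measured", "known", "first", "only" and "open" are said of these compounds alone.

Compound 1 `COc1ccc(CN(C(=O)CCl)c2cc(OC)c(OC)c(OC)c2)cc1O` is the starting point of this step. In a functional assay on HCT-116 cells (Homo sapiens) for inhibition, read by MTT assay, with a stated time of 48 h (a lower number here means a stronger inhibitor, a higher number a weaker inhibitor), compound 1 gives 250 nM, the lowest of the three numbers recorded. Its nearest neighbour is compound 3 `C/C=C/C(=O)N(Cc1ccc(OC)cc1)c1cc(OC)c(OC)c(OC)c1`, which in this assay gives 500 nM, a gap that stays within the usual scatter, so no order between compound 1 and compound 3 can be read from these two values. Furthest away is compound 2 `C/C=C/C(=O)N(Cc1ccc(OC)c(Cl)c1)c1cc(OC)c(OC)c(OC)c1`, which in this assay gives 1420 nM, a gap beyond the scatter. Within the data shown here, the only single-point step among the measured compounds is a 2.8-fold lower number from compound 2 to compound 3 (0.45 log units; beyond the scatter), a change on the aromatic ring, not at the carbonyl.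

Compound 4 `COc1ccc(CN(C(=O)C(C)C)c2cc(OC)c(OC)c(OC)c2)cc1O` is not yet measured. Its change from compound 1 is isopropyl in place of chloromethyl on a carbonyl carbon. Among the measured compounds shown here, no measured step touches the carbonyl carbon alone, so nothing in the data speaks directly to this change; it can only be noted that compound 1 and compound 3, which differ both at the carbonyl and on the ring, give values within the scatter of each other. On that thin basis a modest rise in the number is expected, as a 3.6-fold higher number from compound 1 to compound 4 (0.56 log units; beyond the scatter). Compound 4 is therefore estimated at 900 nM, in a range from 300 nM to 3000 nM.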

Compound 4, half-maximal inhibitory concentration: 310 nM
Compound 4: middle estimate off by 2.9-fold (0.46 log units), on the high side; the measured number falls inside the stated range.
By their numbers in this assay, from the lowest: compounds 1, 4 and 3 (each within the scatter of the next); then compound 2.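

In this assay, among these compounds, isopropyl in place of chloromethyl on a carbonyl carbon gives a 1.2-fold higher number from compound 1 to compound 4 (0.09 log units; within the scatter), the first measured step that changes this position and nothing else. The two compounds therefore cannot be ordered, and within this one pair the loss of the chlorine, with a branched all-carbon group entering in its place, leaves the number within the scatter, so chloromethyl is not needed here to keep the value at this level. No measured evidence on any property of these groups bears on this result, so the step itself can be stated but no reason for it can be given.

The compounds shown leave open whether the same holds for other groups on this carbonyl carbon, such as an aminomethyl group, a carboxylic acid or a longer alkyl chain, and whether it holds with a different substitution on the ring. Compound 3 differs from compound 1 and from compound 4 in more than one place, so the carbonyl group of compound 3 and the ring hydroxyl of compound 1 and compound 4 remain unseparated.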